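The source may hold more compounds than are shown below. What is called first, only, known or untested is meant among the compounds shown, and "the series" means these compounds.

Working notes on the series in a functional assay on BGC-823 cells (Homo sapiens) for inhibition, read by MTT assay, with a stated time of 72 h; a lower number here means a stronger inhibitor, a higher number a weaker inhibitor. Compound 1, `Cc1cc(N2CC[C@@H](C)[C@@H](N(C)c3ncnc4[nH]ccc34)C2)n2nc(SCc3nc4ccccc4[nH]3)nc2n1`, gives > 100000 nM in this assay, which is a limit of the assay rather than a number. Compound 2, `Cc1nc2nc(SCc3ccc(Cl)cc3)nn2c(N2CC[C@@H](C)[C@@H](N(C)c3ncnc4[nH]ccc34)C2)c1C`, likewise returns only a limit, > 100000 nM. Among the measured compounds shown here, both known values therefore sit at the limit of > 100000 nM in this assay, at which 2 of the 2 values shown sit, so compound 1 stands at the upper edge of what this assay reports, with no measured number in the set to rank it against and no step between measured compounds to draw on. Compound 3, `COc1ccc(CSc2nc3nc(C)cc(N4CC[C@@H](C)[C@@H](N(C)c5ncnc6[nH]ccc56)C4)n3n2)cc1`, differs from compound 1 by 4-methoxyphenyl in place of 1H-benzimidazol-2-yl on a saturated chain carbon bound to a sulfur. With both known values at the limit, the data give no direction for this change, and no step beyond the scatter is expected in this assay; compound 3 is expected to stay at or close to the limit. The estimate for compound 3 is 100000 nM, within 30000 nM to 300000 nM, corresponding to an expected step of a number no higher from compound 1 to compound 3 (the limit leaves the size open).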

Compound 3, half-maximal inhibitory concentration: 69900 nM
Compound 3: middle estimate off by 1.4-fold (0.16 log units), on the high side, and the stated range covers the measured number.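

Among the compounds shown here, compound 3 gives the first measured number of the series in this assay, showing that a group on a saturated chain carbon bound to a sulfur can bring a value inside the reported range. Placing 4-methoxyphenyl there instead of 1H-benzimidazol-2-yl gives an at least 1.4-fold lower number from compound 1 to compound 3 (0.15 log units; that floor lies within the scatter), so the data show a floor and not a full size for this change, and that floor gives no firm direction. The measured number still stands alone, with most of the series at the edge of what the assay reports: the limit of > 100000 nM in this assay, at which 2 of the 3 values shown sit.

Still open, on these data alone, is how the number would respond to an amine or a carboxylic acid in place of 4-methoxyphenyl, or to a longer chain at this place. For the compounds shown here, compound 2 differs from compound 3 in more than one place, and no step to it can be read.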